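Lengthening a Carbamate Chain and Its Effect on Lipophilicity

This account rests on a few compounds, and the source may have more. Where it says the series, first, only, none or still open, it means among the compounds named here.

Compound 1 `CCCCCCCCNC(=O)Oc1ccc(Cl)cc1C(=O)Nc1ccc(Cl)c(Cl)c1` and compound 2 `CCCCCCCCCNC(=O)Oc1ccc(Cl)cc1C(=O)Nc1ccc(Cl)c(Cl)c1` share one core and differ only in the length of a saturated chain. In a physicochemical assay for lipophilicity (a lower number here means a more polar compound, a higher number a more lipophilic compound), compound 1 gives 6.92, and compound 2 gives 7.34. The change between them, (methyl in place of hydrogen on a saturated chain carbon, eight bonds along the chain from an amide-type nitrogen), made a step of a number 0.42 log units higher from compound 1 to compound 2 (beyond the scatter). Compound 3 `CCCCCCCCCCNC(=O)Oc1ccc(Cl)cc1C(=O)Nc1ccc(Cl)cc1` carries a different core, and how that core differs from the core of compound 1 is not broken down here. In this assay compound 3 gives 7.19. Compound 4 `CCCCCCCCCCCNC(=O)Oc1ccc(Cl)cc1C(=O)Nc1ccc(Cl)cc1` has not yet been measured in this assay. It differs from compound 3 by methyl in place of hydrogen on a saturated chain carbon, ten or more bonds along the chain from an amide-type nitrogen. Set beside the change from compound 1 to compound 2, the new methyl sits at a different place along the chain from an amide-type nitrogen, so this is the same kind of change, not the same change. Within the data shown here, for compound 4 the step is expected to be a number 0.41 log units higher from compound 3 to compound 4 (beyond the scatter), because a number 0.42 log units higher from compound 1 to compound 2 (beyond the scatter) is the only comparable step at hand. On that basis compound 4 is estimated at 7.6, most likely between 7.3 and 7.9.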

Compound 4, partition coefficient: 7.61
Estimate against measurement, compound 4: 0.01 log units below, and the stated range covers the measured number.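

In this assay, methyl in place of hydrogen on a saturated chain carbon, ten or more bonds along the chain from an amide-type nitrogen, gave a step of a number 0.42 log units higher from compound 3 to compound 4 (beyond the scatter), and this matches in size the step of a number 0.42 log units higher from compound 1 to compound 2 (beyond the scatter) on the core of compound 1, where the new methyl sits eight bonds along the chain. On these two cores, then, the change carried over with its size intact, but this is a single pair of steps in which both the core and the place on the chain differ, so it does not show that the size would hold on any other core or that either difference alone leaves it untouched. Nothing available explains why the two steps agree.

The compounds shown leave open whether a chain longer than that of compound 4 would give a step of the same size. They also leave open what the same change would do on a chain carrying an amine or a carboxylic acid.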